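Chain extension on the thiourea nitrogen and cytotoxicity

This account rests on a few compounds, and the source may have more. Where it says the series, first, only, none or still open, it means among the compounds named here.

Compound 1 `NC(=S)Nc1cccc(OCCCCCc2ccccc2)c1` carries an unsubstituted thiourea; compound 2 `CNC(=S)Nc1cccc(OCCCCCc2ccccc2)c1` bears a methyl and compound 3 `CCNC(=S)Nc1cccc(OCCCCCc2ccccc2)c1` an ethyl on the amide-type nitrogen. In an ADME assay on Ava5 cells (Homo sapiens) for cytotoxicity (a higher number here means that more compound is tolerated, a lower number that less compound is tolerated), compound 1 gives 22000 nM. For compound 2 the read-out in this assay is a limit of the assay, > 50000 nM. For compound 3 the read-out in this assay is likewise a limit of the assay, > 50000 nM. Compound 3 thus stands at the highest level among the numbers shown, with no number of its own, see (the limit of > 50000 nM in this assay, at which 2 of the 3 values shown sit). The steps of an at least 2.2-fold higher number from compound 1 to compound 2 (0.35 log units; beyond the scatter) and an at least 2.2-fold higher number from compound 1 to compound 3 (0.35 log units; beyond the scatter) are both beyond the scatter, whereas a step that the two limits leave unreadable from compound 2 to compound 3 cannot be sized. Compound 4 `CCCNC(=S)Nc1cccc(OCCCCCc2ccccc2)c1` differs from compound 3 by methyl in place of hydrogen on a saturated chain carbon, two bonds along the chain from an amide-type nitrogen. The two readable steps in this assay show no loss of tolerance on lengthening the nitrogen substituent, and the step from the methyl to the ethyl compound has no readable size. The expected step in this assay is therefore a step that the limit leaves unreadable from compound 3 to compound 4, none beyond the scatter. The estimated value for compound 4 is 60000 nM, with a range from 35000 nM to 150000 nM, most likely again reported only as a limit.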

Compound 4, half-maximal cytotoxic concentration: 32000 nM
Compound 4: the middle estimate sits 1.9-fold (0.27 log units) above what was measured; the whole stated range lies above it.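

Of the substituted thioureas shown, only the propyl compound gives a number of its own in this assay, with an at least 1.5-fold lower number from compound 3 to compound 4 (0.19 log units; that floor lies within the scatter) and an at least 1.5-fold lower number from compound 2 to compound 4 (0.19 log units; that floor lies within the scatter). Both floors lie within the scatter, so neither step establishes a loss of tolerance on extending the chain from methyl or ethyl to propyl. The step of a 1.5-fold higher number from compound 1 to compound 4 (0.16 log units; within the scatter) is also within the scatter, so the two cannot be told apart, and the gain in tolerance read for methyl and ethyl over hydrogen is not shown for propyl.

Compound 2 and compound 3 remain at a limit of the assay, so how far either truly lies from the propyl compound stays open: the limit of > 50000 nM in this assay, at which 2 of the 4 values shown sit.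

Also open, from the compounds shown here alone, is where a longer chain such as butyl, a branched isopropyl group or a chain ending in an amine would stand on this nitrogen.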